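A few compounds are considered here, and "the series" means these few. Any claim that something is new, unique, unknown or untested is made for them only; others in the source may bear on it.

Measured in a functional assay on HL-60 cells (Homo sapiens) for antiproliferative activity, read by XTT assay, with a stated time of 72 h; on this read-out higher numbers stand for weaker inhibition and lower numbers for stronger inhibition:
- Compound 1 `CNc1ncnc2c1c(-c1cccs1)cn2[C@@H]1O[C@H](CO)[C@@H](O)[C@H]1O`: > 20000 nM
- Compound 2 `Cc1ncnc2c1c(-c1ccoc1)cn2[C@@H]1O[C@H](CO)[C@@H](O)[C@H]1O`: > 15000 nM

Neither compound has a measured potency yet. Compound 2 gives > 15000 nM, which is a limit and not a number. Compound 1 gives > 20000 nM, which is also a limit. Among the compounds with values here, the two therefore cannot be ranked against each other, and no measured step is available as a guide.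

The next compound is compound 3 `Cc1ncnc2c1c(-c1cccs1)cn2[C@@H]1O[C@H](CO)[C@@H](O)[C@H]1O`, which differs from compound 2 in a single place: thiophen-2-yl in place of furan-3-yl on an aromatic carbon. The swap puts thiophen-2-yl in place of furan-3-yl on an aromatic carbon of the five-membered aromatic ring of the shared core. That group alone gives no assurance of activity, since compound 1 also carries thiophen-2-yl and gives > 20000 nM, a limit.

Even so, some gain in this assay seems possible, though the evidence for it is thin. The expected change, an at least 6.0-fold lower number from compound 2 to compound 3 (0.77 log units; beyond the scatter), is a tentative estimate toward stronger inhibition. Compound 3 is estimated at 2500 nM, with an expected range of 200 nM to 20000 nM.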

Compound 3, half-maximal inhibitory concentration: 5730 nM
Estimate against measurement, compound 3: 2.3-fold (0.36 log units) below, within the range that was stated.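

In this assay, within the data shown here, thiophen-2-yl in place of furan-3-yl on an aromatic carbon of the five-membered ring gives an at least 2.6-fold lower number from compound 2 to compound 3 (0.41 log units; beyond the scatter), so the choice between these two rings at this place matters, and compound 3 is the first of the three compounds to give a measured number rather than a limit. Thiophen-2-yl is not enough by itself, however: methyl in place of methylamino on an aromatic carbon, at a second place on the shared core, gives an at least 3.4-fold lower number from compound 1 to compound 3 (0.54 log units; beyond the scatter), so the result depends on the group at that second place as well. Both steps start from a limit of the assay and not from a number, and each gives only a smallest size, with the true size unknown.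

Going by these compounds, what remains open is whether the gain belongs to sulfur in the ring or to the way the ring is attached, a question that furan-2-yl or thiophen-3-yl at the same place could answer. On these data alone, it is also open how a longer chain such as ethyl, or an amine such as dimethylamino, would behave in place of methyl when thiophen-2-yl is kept.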